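Adding a Methoxy Group to a Pyrazoline Sulfonamide Series

The compounds below may be only part of what the source reports. "The series", "measured", "known", "first", "only" and "open" are said of these compounds alone.

The measured compounds and their numbers in a functional assay on SK-MEL-5 cells (Homo sapiens) for antiproliferative activity, with a stated time of 48 h; a higher number here means that more compound is tolerated, a lower number that less compound is tolerated:
compound 1, `Cc1cc(O)c(C2=NN(c3ccc(S(N)(=O)=O)cc3)C(c3ccccc3O)C2)cc1Cl`, gives 42700 nM;
compound 2, `Cc1cc(O)c(C2=NN(c3ccc(S(N)(=O)=O)cc3)C(c3ccccc3Cl)C2)cc1Cl`, gives 36000 nM;
compound 3, `COc1ccc(C2CC(c3cc(Cl)c(C)cc3O)=NN2c2ccc(S(N)(=O)=O)cc2)cc1OC`, gives 39700 nM.

Compound 3 stands second highest of the three numbers in this assay, but its nearest neighbour is compound 1 and its furthest is compound 2, and both gaps lie within the scatter, so the three compounds cannot be told apart on these data.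

Compound 4, `COc1ccc(C2CC(c3cc(Cl)c(C)cc3O)=NN2c2ccc(S(N)(=O)=O)cc2)c(OC)c1OC`, differs from compound 3 by methoxy in place of hydrogen on an aromatic carbon. Among the measured compounds shown here, no measured step places a methoxy group on this ring; the steps that touch this part of the molecule exchange the whole aryl group, and they read a 1.1-fold lower number from compound 1 to compound 3 (0.03 log units; within the scatter) and a 1.1-fold higher number from compound 2 to compound 3 (0.04 log units; within the scatter), neither beyond the scatter. The step of a 1.2-fold lower number from compound 1 to compound 2 (0.07 log units; within the scatter) at the other aryl group is likewise within the scatter. For the measured compounds named here, since no change at this position has moved the number so far, compound 4 is expected to show a 1.0-fold higher number from compound 3 to compound 4 (0.00 log units; within the scatter), with an estimated value of 40000 nM and a range from 20000 nM to 80000 nM.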

Compound 4, concentration lethal to 50% of the cells: 8650 nM
The estimate for compound 4 lay 4.6-fold (0.67 log units) above the measured number, and the stated range ends above it.
By their numbers in this assay, from the lowest: compound 4; then compounds 2, 3 and 1 (each within the scatter of the next).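

In this assay, among the compounds shown here, the step of a 4.6-fold lower number from compound 3 to compound 4 (0.66 log units; beyond the scatter) shows that, unlike the earlier steps, a change on this aryl group can move the number beyond the scatter, and that a single methoxy in place of hydrogen, ortho to a large group and ortho to a methoxy group, is enough to do so. The 2,3,4-trimethoxyphenyl group also stands apart from the aryl groups of the other two compounds, with a 4.2-fold lower number from compound 2 to compound 4 (0.62 log units; beyond the scatter) and with a 4.9-fold lower number from compound 1 to compound 4 (0.69 log units; beyond the scatter), while exchanges among those earlier groups stayed within the scatter. Nothing available here explains this shift.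

The compounds shown leave open whether the lower number needs all three methoxy groups together or would follow from a methoxy group at this place alone. They also leave open how an ethoxy group or an amine at the same place would read.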